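The compounds below may be only part of what the source reports. "The series", "measured", "known", "first", "only" and "open" are said of these compounds alone.

Compound 1 `Cc1cnc(Nc2ccc(S(C)(=O)=O)cc2)nc1Nc1nc2ccc(Cl)cc2s1` and compound 2 `Cc1cnc(Nc2ccc(S(N)(=O)=O)cc2)nc1Nc1nc2ccc(Cl)cc2s1` were both tested in a functional assay on MCF7 cells (Homo sapiens) for antiproliferative activity, read by MTT assay, with a stated time of 48 h; a higher number here means a weaker inhibitor, a lower number a stronger inhibitor. Compound 1 gives 4320 nM, and compound 2 gives 8430 nM. Among the measured compounds shown here, the only measured step, a 2.0-fold higher number from compound 1 to compound 2 (0.29 log units; within the scatter), alters a single group at the sulfonyl sulfur and stays within the scatter, so compound 2 stands at the higher of the two numbers without being separable from compound 1. Compound 3 `Cc1cnc(Nc2ccc(S(N)(=O)=O)cc2)nc1Nc1nc2ccc(F)cc2s1` differs from compound 2 in one place: fluoro in place of chloro on an aromatic carbon. For the measured compounds named here, no measured step concerns a halogen on this ring, so nothing in hand shows how this exchange shifts the number. Going by the values given here, the one step that has been measured touches a different part of the molecule and was small. For compound 3 a small shift is therefore expected, a 1.2-fold higher number from compound 2 to compound 3 (0.07 log units; within the scatter), with no direction beyond the scatter. Compound 3 is expected to give about 10000 nM, within a range from 3000 nM to 30000 nM.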

Compound 3, half-maximal inhibitory concentration: > 50000 nM
Compound 3: no number, only a limit; the forecaster's own chance of this, stated with the estimate: 10%; middle value at least 5.0-fold (0.69 log units) from the limit.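

In this assay compound 3 gives only a limit of the assay, not a number: the limit of > 50000 nM in this assay, at which 1 of the 3 values shown sits. Fluoro in place of chloro on this aromatic carbon is the first change shown that reaches beyond the scatter, with an at least 5.9-fold higher number from compound 2 to compound 3 (0.77 log units; beyond the scatter). The halogen position therefore proves far more sensitive than the sulfonyl sulfur, where amino in place of methyl stayed within the scatter, even though chloro and fluoro are each a single heavy atom.

On these data alone, the true size of this step stays open, as does whether the same exchange would matter as much with the methyl on the sulfonyl sulfur of compound 1. As far as these compounds go, what a bromo group, a methoxy group or a plain hydrogen would give on this carbon also remains open, so the result cannot yet be tied to chloro itself.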